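Chloro for Fluoro on the Phenoxymethyl Side Chain

The source may hold more compounds than are shown below. What is called first, only, known or untested is meant among the compounds shown, and "the series" means these compounds.

Measured so far in an assay on HEK293 cells for agonist activity at prostaglandin E2 receptor EP2 subtype (Homo sapiens), read by a beta-galactosidase reporter and beta-arrestin recruitment, with a stated time of 90 min; a lower number here means that less compound is needed, a higher number that more compound is needed for the effect:
compound 1 `O=C(O)c1csc([C@H]2CC[C@@H]3[C@@H](CCCCCOc4ccccc4)[C@H](O)C[C@@H]3O2)n1`: > 10000 nM
compound 2 `O=C(O)c1csc([C@H]2CC[C@@H]3[C@@H](COc4ccc(F)cc4)[C@H](O)C[C@@H]3O2)n1`: > 10000 nM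
compound 3 `O=C(O)c1csc([C@H]2CC[C@@H]3[C@@H](COc4cccc(F)c4)[C@H](O)C[C@@H]3O2)n1`: > 10000 nM

Compound 1 gives only a limit of the assay in this assay, namely > 10000 nM. Compound 2 likewise gives a limit, > 10000 nM. Compound 3 also gives a limit, > 10000 nM. The move from 4-fluorophenyl to 3-fluorophenyl is therefore a step that the two limits leave unreadable from compound 2 to compound 3, and compound 3 stands with the rest at the limit of > 10000 nM in this assay, at which 3 of the 3 values shown sit.

Compound 4 `O=C(O)c1csc([C@H]2CC[C@@H]3[C@@H](COc4cccc(Cl)c4)[C@H](O)C[C@@H]3O2)n1` differs from compound 3 in one place: chloro in place of fluoro on an aromatic carbon. Within the data shown here, the only neighbouring step, from compound 2 to compound 3, is unreadable, so no measured step gives a size or a direction for swapping 3-fluorophenyl for 3-chlorophenyl here. With every value shown sitting at the limit, no step beyond the scatter is expected, and the estimated step is a step that the limit leaves unreadable from compound 3 to compound 4. Compound 4 is accordingly expected to give 15000 nM, with a range from 3000 nM to 60000 nM, and most probably only a limit again.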

Compound 4, half-maximal effective concentration: > 10000 nM
Compound 4 ended at the assay's limit (the forecaster's own chance of this, stated with the estimate: 80%); the middle value is on the limit's open side.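

In this assay compound 4 gives > 10000 nM, a limit of the assay, so the steps to it from compound 2 and compound 3 cannot be read, and all four compounds remain at one limit: the limit of > 10000 nM in this assay, at which 4 of the 4 values shown sit.

The compounds shown leave open whether any change on the side chain would bring a value inside the range of this assay.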